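Alkyl on the aromatic nitrogen: three measured, one pending

The compounds below may be only part of what the source reports. "The series", "measured", "known", "first", "only" and "open" are said of these compounds alone.

Measured in an assay on HEK-293T cells for antagonist activity at vitamin D3 receptor (Homo sapiens), read by a luciferase reporter, with a stated time of 24 h; on this read-out lower numbers stand for stronger inhibition and higher numbers for weaker inhibition:
compound 1 `CC(C)c1onc(-c2c(Cl)cccc2Cl)c1COc1ccc(-c2nc3ccc(C(=O)O)cc3n2C)cc1`: 7150 nM
compound 2 `CC(C)c1onc(-c2c(Cl)cccc2Cl)c1COc1ccc(-c2nc3ccc(C(=O)O)cc3n2C2CC2)cc1`: 3200 nM
compound 3 `CC(C)Cn1c(-c2ccc(OCc3c(-c4c(Cl)cccc4Cl)noc3C(C)C)cc2)nc2ccc(C(=O)O)cc21`: 1180 nM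

Compound 3 gives the lowest number of the three; the steps of a 6.1-fold lower number from compound 1 to compound 3 (0.78 log units; beyond the scatter) and a 2.7-fold lower number from compound 2 to compound 3 (0.43 log units; beyond the scatter) both lie beyond the scatter, as does a 2.2-fold lower number from compound 1 to compound 2 (0.35 log units; beyond the scatter). Compound 4 `CC(C)c1onc(-c2c(Cl)cccc2Cl)c1COc1ccc(-c2nc3ccc(C(=O)O)cc3n2C2CCC2)cc1` differs from compound 3 by cyclobutyl in place of isobutyl on an aromatic nitrogen. Going by the values given here, no measured step swaps a branched chain for a ring at the same heavy-atom count; the steps of a 2.2-fold lower number from compound 1 to compound 2 (0.35 log units; beyond the scatter) and a 2.7-fold lower number from compound 2 to compound 3 (0.43 log units; beyond the scatter) bear on it only indirectly, since cyclobutyl matches isobutyl in count and cyclopropyl in being a ring. A step within or just beyond the scatter is expected, toward a somewhat higher number. Compound 4 is expected to give 1600 nM in this assay, within 600 nM to 4200 nM, a step of a 1.4-fold higher number from compound 3 to compound 4 (0.13 log units; within the scatter).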

Compound 4, half-maximal inhibitory concentration: 1100 nM
Compound 4: the middle estimate sits 1.5-fold (0.16 log units) above what was measured, and the stated range covers the measured number.
By their numbers in this assay, from the lowest: compounds 4 and 3 (each within the scatter of the next); then compound 2; then compound 1.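

In this assay, a ring on the aromatic nitrogen matches the branched chain at the same heavy-atom count, with cyclobutyl in place of isobutyl (a 1.1-fold lower number from compound 3 to compound 4 (0.03 log units; within the scatter)). Being a ring does not by itself hold the number up: cyclobutyl separates from cyclopropyl (a 2.9-fold lower number from compound 2 to compound 4 (0.46 log units; beyond the scatter)) and from methyl (a 6.5-fold lower number from compound 1 to compound 4 (0.81 log units; beyond the scatter)). No evidence on hand accounts for these steps.

Open, going by these compounds, is whether a larger ring such as cyclohexyl or a longer chain such as n-hexyl would lower the number further. Also open, on these data alone, is how an amine carried on this alkyl group would read.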